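Oxadiazole for fluorine on the aryl of the shared core

This account rests on a few compounds, and the source may have more. Where it says the series, first, only, none or still open, it means among the compounds named here.

Measured compounds:
compound 1 `Fc1ccc(-c2nc3cccnc3n2C2CCCC2)cc1` — 500 nM in a functional assay on MDA-MB-231 cells (Homo sapiens) for cytotoxicity, read by MTT assay, with a stated time of 24 h; a lower number here means a stronger inhibitor, a higher number a weaker inhibitor
compound 2 `Fc1cc(F)cc(-c2nc3cccnc3n2C2CCCC2)c1` — 138 nM
compound 3 `c1cnc2c(c1)nc(-c1cncnc1)n2C1CCCC1` — > 10000 nM, which is a limit of the assay and not a number

Compound 1 stands at the highest of the two numbers in this assay; its nearest neighbour is compound 2, whose number is lower by a margin beyond the scatter. Compound 3 gives only a limit. Among the compounds with values here, the one step measured with a single change is an at least 20-fold higher number from compound 1 to compound 3 (1.30 log units; beyond the scatter), where the aryl group itself is exchanged and the value reaches (the limit of > 10000 nM in this assay, at which 1 of the 3 values shown sits).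

Compound 4 `Cc1nnc(-c2ccc(-c3nc4cccnc4n3C3CCCC3)cc2)o1` keeps the aryl group of compound 1 and alters it at one position: 5-methyl-1,3,4-oxadiazol-2-yl in place of fluoro on an aromatic carbon. The group enters on an aromatic carbon of a six-membered aromatic ring of carbon only, para to a large group. Within the data shown here, no measured step bears directly on this change: the step from compound 1 to compound 3 exchanges the whole aryl group, while here a substituent on that group is replaced. The step is therefore expected to be small, probably toward a somewhat higher number. For compound 4 the expectation is 900 nM, with a range from 200 nM to 4000 nM, which as a step is a 1.8-fold higher number from compound 1 to compound 4 (0.26 log units; within the scatter), awaiting the measurement.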

Compound 4, half-maximal inhibitory concentration: 21 nM
Estimate against measurement, compound 4: 43-fold (1.63 log units) above; measured number below the stated range.
By their numbers in this assay, from the lowest: compound 4; then compound 2; then compound 1. At a limit, above all of these: compound 3.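

The aromatic carbon para to a large group takes far more than a single fluoro: in this assay, 5-methyl-1,3,4-oxadiazol-2-yl in place of fluoro gives a 24-fold lower number from compound 1 to compound 4 (1.38 log units; beyond the scatter). Within the data shown here, the earlier single-change step replaced the whole aryl group and moved the other way, with an at least 20-fold higher number from compound 1 to compound 3 (1.30 log units; beyond the scatter), so this is the first sign that a substituent at this position, with its five-membered aromatic ring, can lower the number while the phenyl ring stays in place. Nothing measured here accounts for the size of this step.

Still open, as far as these compounds go, is whether the lower number depends on the oxadiazole ring or on its methyl group, a question that the unsubstituted 1,3,4-oxadiazol-2-yl, an amide, a nitrile or a carboxylic acid on the same carbon could help to settle. Also open, from the compounds shown here alone, is whether the same group would bring a step of similar size on the aryl group of compound 2, and whether a longer chain in place of the methyl would keep the number of compound 4.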